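The source may report more compounds than this note shows. Statements on the series, on what has been measured and on what is new or still open speak of the compounds shown alone.

Measured compounds in a functional assay on MCF7 cells (Homo sapiens) for antiproliferative activity; a higher number here means a weaker inhibitor, a lower number a stronger inhibitor:
compound 1 `CC/C=C\Cn1c(Cc2cc(OC)c(OC)c(OC)c2)nc2c(N)ncnc21` gives 64600 nM
compound 2 `C#CCCn1c(Cc2cc(OC)c(OC)c(OC)c2)nc2c(N)nc(F)nc21` gives 25100 nM
compound 3 `C=CCCCn1c(Cc2cc(OC)c(OC)c(OC)c2)nc2c(N)nc(F)nc21` gives 44700 nM

Compound 1 gives the highest of the three numbers. Compound 3 sits within the scatter of it, so no order between those two is claimed; compound 2 lies beyond the scatter, with a lower number. Compound 4 `C/C=C/Cn1c(Cc2cc(OC)c(OC)c(OC)c2)nc2c(N)ncnc21` is not yet measured. It differs from compound 1 in one place: prop-1-en-1-yl in place of but-1-en-1-yl on a saturated chain carbon bound to an aromatic nitrogen. The chain on the aromatic nitrogen is thus shortened from pent-2-en-1-yl to but-2-en-1-yl, the double bond kept.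

Among the measured compounds shown here, one measured step concerns a change of the chain on the aromatic nitrogen, though on a core carrying fluorine: a 1.8-fold higher number from compound 2 to compound 3 (0.25 log units; within the scatter). That step swaps the end of the chain and is within the scatter. For the measured compounds named here, no measured step removes a single chain carbon on the core of compound 1 itself, so the direction of the change is open. Given that the only comparable step is small, the expected step from compound 1 to compound 4 is also small, a 1.2-fold lower number from compound 1 to compound 4 (0.07 log units; within the scatter), and not beyond the scatter in either direction. Compound 4 is therefore estimated at 55000 nM in this assay, with a range from 20000 nM to 150000 nM.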

Compound 4, half-maximal inhibitory concentration: 51300 nM
Compound 4: middle estimate off by 1.1-fold (0.03 log units), on the high side; low and high end bracket the measured number.
By their numbers in this assay, from the lowest: compounds 2, 3, 4 and 1 (each within the scatter of the next, the first and the last beyond it).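

Working notes on the chain on the aromatic nitrogen. On the core of compound 1, which carries no fluorine, taking the chain from pent-2-en-1-yl to but-2-en-1-yl with the double bond kept gives a 1.3-fold lower number from compound 1 to compound 4 (0.10 log units; within the scatter) in this assay. Among the compounds shown here, this is the first step that removes a single chain carbon rather than swapping the chain end on the fluorinated core, and it shows that, at this position and for this pair, that shortening gives no readable change in the number, so no order between the two compounds is claimed. No measurement at hand bears on why the number holds across this change.

The double bond is also drawn with opposite geometry in compound 1 and compound 4, so this pair cannot separate chain length from geometry, and no pair shown isolates the fluorine on the core. Also open, going by these compounds, is whether a polar end group on the chain, such as an amine or a carboxylic acid, or a much longer chain would move the number beyond the scatter.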